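The source may report more compounds than this note shows. Statements on the series, on what has been measured and on what is new or still open speak of the compounds shown alone.

Measured in an ADME assay on microsomes from liver (Mus musculus) for metabolic stability, with a stated time of 10 min; a lower number here means that less of the compound is left, a higher number that more of the compound is left:
- Compound 1 `CC(=O)N1CC[C@H](C(=O)N2CC[C@](c3ccc(C(OCc4c(F)cccc4F)(C(F)(F)F)C(F)(F)F)cc3)(S(=O)(=O)c3ccc(F)cc3)C2)C1`: 57%
- Compound 2 `O=C(O)[C@H]1CC[C@H](C(=O)N2CC[C@](c3ccc(C(OCc4ccccc4OC(F)(F)F)(C(F)(F)F)C(F)(F)F)cc3)(S(=O)(=O)c3ccc(F)cc3)C2)CC1`: 81%

Of these two, compound 2 stands higher, and its gap to compound 1 lies beyond the scatter. Compound 3 `O=C(O)[C@H]1CC[C@H](C(=O)N2CC[C@](c3ccc(C(OCC4CCC4)(C(F)(F)F)C(F)(F)F)cc3)(S(=O)(=O)c3ccc(F)cc3)C2)CC1` carries cyclobutyl in place of 2-(trifluoromethoxy)phenyl on a saturated chain carbon bound to an oxygen on a saturated carbon. Going by the values given here, compounds 1 and 2 differ in more than one place, so no measured step isolates this change. A small downward shift in this assay is expected, with an estimated a number 9 percentage points lower from compound 2 to compound 3 (within the scatter). Compound 3 is expected at 72%, within an estimated range of 52% to 90%.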

Compound 3, percent of the compound remaining: 39%
Estimate against measurement, compound 3: 33 percentage points above; measured number outside the range, below it.
By their numbers in this assay, from the lowest: compound 3; then compound 1; then compound 2.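

In this assay, putting cyclobutyl in place of 2-(trifluoromethoxy)phenyl on a saturated chain carbon bound to an oxygen on a saturated carbon gives a number 42 percentage points lower from compound 2 to compound 3 (beyond the scatter), a large step beyond the scatter. Going by these compounds alone, compound 1 and compound 2 differ in more than one place, so this is the first reading of this position alone, and it shows that the change matters strongly for the compound remaining. Nothing available explains this step. As far as these compounds go, what plain phenyl or cyclohexyl would give at this place stays open, as does whether the aromatic ring or the trifluoromethoxy group counts for more.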